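A few compounds are considered here, and "the series" means these few. Any claim that something is new, unique, unknown or untested is made for them only; others in the source may bear on it.

Values so far in an ADME assay on MT4 cells (Homo sapiens) for cytotoxicity, with a stated time of 5 days; on this read-out higher numbers stand for lower toxicity in this test and lower numbers for higher toxicity in this test

compound 1 `O=C1CN(S(=O)(=O)c2cc(F)cc(F)c2)c2cc(Cl)ccc2N1` gives 187000 nM
compound 2 `O=C1CN(S(=O)(=O)c2cc(Cl)cc(Cl)c2)c2cc(Cl)ccc2N1` gives >= 205000 nM (a limit)
compound 3 `O=c1[nH]c2ccc(Cl)cc2n1S(=O)(=O)c1ccccc1F` gives > 382000 nM (a limit)

Going by these compounds, for compound 3, the entry > 382000 nM is a limit of the assay and not a number, so its exact place is unknown. For compound 2, the entry >= 205000 nM is also a limit of the assay. Among the measured compounds shown here, compound 1 carries the only exact reading, at 187000 nM.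

The next compound to be tested is compound 4 `O=c1[nH]c2ccc(Cl)cc2n1S(=O)(=O)c1ccc(F)cc1`. It carries 4-fluorophenyl in place of 2-fluorophenyl on a sulfonyl sulfur.

For the measured compounds named here, no measured pair differs in one place only, so this assay offers no direct precedent for this swap. No shift beyond the usual scatter is expected, in either direction. Compound 3 remains the closest reference for this expectation, with its limit of > 382000 nM. The expected change, an at least 1.1-fold lower number from compound 3 to compound 4 (0.05 log units; that floor lies within the scatter), is estimated to stay within the scatter, and another limit rather than a number is the more likely report. For compound 4 the estimated value is 340000 nM, with an expected range from 150000 nM to 420000 nM.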

Compound 4, half-maximal cytotoxic concentration: >= 355000 nM
Compound 4: a limit, no number; the forecaster's own chance of this, stated with the estimate: 65%; middle value at least 1.0-fold (0.01 log units) from the limit.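

In this assay compound 3 gives > 382000 nM, a limit of the assay. Compound 4 gives >= 355000 nM, also a limit, so no step can be read between compound 3 and compound 4. The compounds shown leave open whether 4-fluorophenyl and 2-fluorophenyl on a sulfonyl sulfur differ at all in this assay.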